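Selenium alkylation across two cores: notes on compound 4

The source may report more compounds than this note shows. Statements on the series, on what has been measured and on what is new or still open speak of the compounds shown alone.

Measured so far:
Compound 1 `Nc1nc([SeH])nc2ncccc12`: 96600 nM
Compound 2 `CCCCC[Se]c1nc(N)c2cccnc2n1`: 51000 nM
Compound 3 `Nc1nc([SeH])nc2ccccc12`: 3630 nM

The values above come from a functional assay on HTB-54 cells (Homo sapiens) for cytotoxicity, read by MTT assay, with a stated time of 72 h; on this read-out higher numbers stand for weaker inhibition of growth and lower numbers for stronger inhibition of growth. Compound 1 gives 96600 nM and compound 2 gives 51000 nM; the two differ by one change, (pentyl in place of hydrogen on a selenium), and the step recorded for it is a 1.9-fold lower number from compound 1 to compound 2 (0.28 log units; within the scatter). Compound 3, on a different core, gives 3630 nM, the lowest number among the three, with its gaps to compound 1 and compound 2 both beyond the usual scatter. The difference between the core of compound 1 and the core of compound 3 is not broken down here.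

Compound 4 `CCCCC[Se]c1nc(N)c2ccccc2n1` is not yet measured. It stands to compound 3 as compound 2 stands to compound 1: the change is pentyl in place of hydrogen on a selenium, the same change in the same place, and it has been seen once before in this set. Among the compounds with values here, the only guide to its size is the step from compound 1 to compound 2, which in this assay stayed within the scatter. It is therefore expected that the step from compound 3 to compound 4 will be small as well, about a 1.5-fold lower number from compound 3 to compound 4 (0.18 log units; within the scatter), because the earlier case gave a 1.9-fold lower number from compound 1 to compound 2 (0.28 log units; within the scatter). Whether the change behaves the same on the core of compound 3 cannot be checked from one prior example, so the expected range is kept wide. The estimate for compound 4 in this assay is 2400 nM, with a range from 900 nM to 6500 nM.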

Compound 4, concentration for total growth inhibition: 84000 nM
Compound 4: middle estimate off by 35-fold (1.54 log units), on the low side; the whole stated range lies below it.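

In this assay, pentyl in place of hydrogen on a selenium gives a 23-fold higher number from compound 3 to compound 4 (1.36 log units; beyond the scatter) and so takes away most of the growth inhibition seen on this core. The change therefore cannot be carried from the core of compound 1 to the core of compound 3 as a fixed step, and its effect in this series depends on the core that bears it: the same change on two cores in this assay, a 1.9-fold lower number (0.28 log units; within the scatter) from compound 1 to compound 2 and a 23-fold higher number (1.36 log units; beyond the scatter) from compound 3 to compound 4, 44-fold (1.64 log units) apart, beyond the scatter of two such steps

The comparison rests on a single pair on each of two cores, so it does not show which feature of the cores sets the difference, nor how the same change would behave on a third core.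

The compounds shown leave open whether the higher number on the core of compound 3 depends on chain length, which a methyl, a propyl or a longer chain such as octyl on the selenium would help to settle. They also leave open whether a chain-free group such as benzyl, or a pentyl chain ending in an amine or a carboxylic acid, would follow pentyl on either core.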